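The source may report more compounds than this note shows. Statements on the series, on what has been measured and on what is new or still open speak of the compounds shown alone.

Compound 1 `COc1ccc(/C=N/NC(=O)Nc2ccc(Oc3ccnc(-c4nncn4CCN(C)C)c3)c(F)c2)c(OC)c1OC`: in a functional assay on NCI-H460 cells (Homo sapiens) for cytotoxicity, read by MTT assay, with a stated time of 72 h (a lower number here means a stronger inhibitor, a higher number a weaker inhibitor), compound 1 gives 1790 nM.
Compound 2 `COc1cc(/C=N/NC(=O)Nc2ccc(Oc3ccnc(-c4nncn4CCN(C)C)c3)c(F)c2)ccc1O`: in this assay compound 2 gives 57 nM.

For the measured compounds named here, compound 2 holds the lower of the two numbers, and the only measured step, a 31-fold lower number from compound 1 to compound 2 (1.50 log units; beyond the scatter), shows that changing the aryl group on this carbon shifts the read-out strongly. Compound 3 `Cc1cc(/C=N/NC(=O)Nc2ccc(Oc3ccnc(-c4nncn4CCN(C)C)c3)c(F)c2)cc(C)c1O` differs from compound 2 by 4-hydroxy-3,5-dimethylphenyl in place of 4-hydroxy-3-methoxyphenyl on a carbon with a double bond to nitrogen. Going by the values given here, that step keeps the hydroxyl and changes methoxy to methyl groups; no measured step tests such an exchange directly. Compound 2 to compound 3 is therefore expected to move by a 1.6-fold higher number from compound 2 to compound 3 (0.20 log units; within the scatter), within the scatter. Compound 3 is estimated at 90 nM, between 25 nM and 350 nM.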

Compound 3, half-maximal inhibitory concentration: 2010 nM
Beside the measured number, compound 3's estimate is 22-fold (1.35 log units) below it; the whole stated range lies below it.
By their numbers in this assay, from the lowest: compound 2; then compounds 1 and 3 (each within the scatter of the next).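

The step of a 35-fold higher number from compound 2 to compound 3 (1.55 log units; beyond the scatter) keeps the hydroxyl on this carbon's aryl group, so the hydroxyl alone does not secure the low number of compound 2. The step of a 1.1-fold higher number from compound 1 to compound 3 (0.05 log units; within the scatter) stays within the scatter, although these two aryl groups share little in their substitution. For the compounds shown here, no available evidence explains why this exchange moves the number so far.

Because the methoxy group is lost and a pair of methyl groups enters in one step, the compounds shown cannot separate these two changes. They also leave open how an ethoxy group or an amine would behave in place of that methoxy group.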